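The source may report more compounds than this note shows. Statements on the series, on what has been measured and on what is new or still open speak of the compounds shown alone.

In a functional assay on SGC-7901 cells (Homo sapiens) for antiproliferative activity, read by MTT assay, with a stated time of 72 h (a higher number here means a weaker inhibitor, a lower number a stronger inhibitor), compound 1 `COc1cc(-n2cnc3ccc(-c4ccccc4Cl)cc32)cc(OC)c1OC` gives > 10000 nM, which is a limit of the assay. Going by the values given here, compound 2 `COc1cc(-n2cnc3ccc(-c4ccc(C(C)=O)cc4)cc32)cc(OC)c1OC`, at 450 nM, holds the only actual number so far. Compound 3 `COc1cc(-n2cnc3ccc(-c4ccc(C)cc4F)cc32)cc(OC)c1OC` differs from compound 2 by one change, 2-fluoro-4-methylphenyl in place of 4-acetylphenyl on an aromatic carbon, (2-fluoro-4-methylphenyl in place of 4-acetylphenyl on an aromatic carbon). One large measured step bears on this place: an at least 22-fold lower number from compound 1 to compound 2 (1.34 log units; beyond the scatter), which ended at the 4-acetylphenyl group that compound 3 gives up. Part of that gain is expected to be lost in this assay, with an estimated 2.2-fold higher number from compound 2 to compound 3 (0.35 log units; beyond the scatter), far smaller than the measured step. For compound 3 the estimate is 1000 nM, with an expected range of 150 nM to 7000 nM.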

Compound 3, half-maximal inhibitory concentration: 5650 nM
Compound 3: middle estimate off by 5.7-fold (0.75 log units), on the low side; the range from low to high includes it.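

At this position on the shared core, this assay now shows that giving up 4-acetylphenyl is costly: the change to 2-fluoro-4-methylphenyl gives a 13-fold higher number from compound 2 to compound 3 (1.10 log units; beyond the scatter). Replacing 2-chlorophenyl does not by itself secure a large gain, as the other new step is an at least 1.7-fold lower number from compound 1 to compound 3 (0.24 log units; that floor lies within the scatter). That step is read against a limit, not a number: the limit of > 10000 nM in this assay, at which 1 of the 3 values shown sits.

Compound 3 differs from compound 2 in both the acetyl and the fluorine, and the data do not separate the two. On these data alone, how a 4-aminophenyl or 4-carboxyphenyl group would compare at this position remains open.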